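Changing the Aryl End on a Shared Core

A few compounds are considered here, and "the series" means these few. Any claim that something is new, unique, unknown or untested is made for them only; others in the source may bear on it.

Measured compounds:
- compound 1, `O=C(COc1ccc(C(=O)/C=C/c2ccc(Cl)cc2Cl)cc1)N[C@H]1CCOC1=O`: 8040 nM
- compound 2, `CC(C)c1ccc(/C=C/C(=O)c2ccc(OCC(=O)N[C@H]3CCOC3=O)cc2)cc1`: 4660 nM

Both compounds were tested in a functional assay on PC-3 cells (Homo sapiens) for antiproliferative activity, read by MTT assay, with a stated time of 72 h; a lower number here means a stronger inhibitor, a higher number a weaker inhibitor. Compound 1 gives 8040 nM, and compound 2 gives 4660 nM. Among the compounds with values here, the single measured step, a 1.7-fold lower number from compound 1 to compound 2 (0.24 log units; within the scatter), is the only comparison available at this end of the shared core. Compound 2 holds the smaller of the two numbers, but that step is within the scatter, so the two compounds cannot be told apart on what is shown.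

Compound 3, `O=C(COc1ccc(C(=O)/C=C/c2cccc([N+](=O)[O-])c2)cc1)N[C@H]1CCOC1=O`, has not yet been measured. It differs from compound 2 by 3-nitrophenyl in place of 4-isopropylphenyl on a double-bonded chain carbon bound to a double-bonded chain carbon. Within the data shown here, the one step that bears on this position is a 1.7-fold lower number from compound 1 to compound 2 (0.24 log units; within the scatter), and it stayed within the scatter, so there is no measured evidence that exchanging the aryl group here moves the number much in either direction. Compound 3 is therefore expected to land near compound 2, with a 1.3-fold higher number from compound 2 to compound 3 (0.11 log units; within the scatter) as the expected step. The estimate for compound 3 in this assay is 6000 nM, with a range from 2500 nM to 15000 nM.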

Compound 3, half-maximal inhibitory concentration: 56300 nM
Estimate against measurement, compound 3: 9.4-fold (0.97 log units) below; the measured number lies above the stated range.
By their numbers in this assay, from the lowest: compounds 2 and 1 (each within the scatter of the next); then compound 3.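

In this assay, the aryl end of the shared core proved able to move the number: 3-nitrophenyl in place of 4-isopropylphenyl gives a 12-fold higher number from compound 2 to compound 3 (1.08 log units; beyond the scatter), and 3-nitrophenyl in place of 2,4-dichlorophenyl gives a 7.0-fold higher number from compound 1 to compound 3 (0.85 log units; beyond the scatter), whereas the earlier exchange between the other two groups stayed within the scatter. In the step from compound 2 to compound 3, the count of 9 heavy atoms and the single six-membered aromatic ring stay the same, while the entering group brings nitrogen, oxygen and 2 hydrogen-bond acceptors, so these size counts do not track the change in the number. Nothing measured here accounts for the rise seen with 3-nitrophenyl.

The compounds shown leave open whether the higher number follows the nitro group itself or its place on the phenyl ring, a question that 4-nitrophenyl would address. They also leave open whether an amine, a nitrile or a carboxylic acid in the place of the nitro group would give a number close to compound 3 or close to compound 2.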